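The source may report more compounds than this note shows. Statements on the series, on what has been measured and on what is new or still open speak of the compounds shown alone.

Compound 3 `CCCc1ccc(OCc2ccc(C(=O)Nc3ccccc3N)cc2)cc1` gives 5210 nM in a functional assay on A549 cells (Homo sapiens) for antiproliferative activity, read by CCK-8 assay, with a stated time of 72 h (a lower number here means a stronger inhibitor, a higher number a weaker inhibitor), the lowest of the three numbers at hand. Compound 1 `O=C(/C=C/c1ccc(COc2ccccc2)cc1)NO` gives 5770 nM in this assay, a gap from compound 3 that stays within the scatter, while compound 2 `O=C(NO)c1ccc(COc2ccccc2)cc1` gives 28000 nM, a gap from compound 3 that lies beyond the scatter. Going by the values given here, the one measured step, a 4.9-fold higher number from compound 1 to compound 2 (0.69 log units; beyond the scatter), concerns a different part of the molecule and does not bear on the change to compound 4 `CCc1ccc(OCc2ccc(C(=O)Nc3ccccc3N)cc2)cc1`, which is hydrogen in place of methyl on a saturated chain carbon, two bonds along the chain from an aromatic carbon. Among the compounds with values here, no measured step touches this chain, so compound 4 is expected to stay within the scatter of compound 3, with an expected step of a 1.1-fold higher number from compound 3 to compound 4 (0.05 log units; within the scatter). Compound 4 is estimated at 5800 nM in this assay, with a range from 2500 nM to 13000 nM.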

Compound 4, half-maximal inhibitory concentration: 6420 nM
Compound 4: middle estimate off by 1.1-fold (0.04 log units), on the low side; measured number inside the range.
By their numbers in this assay, from the lowest: compounds 3, 1 and 4 (each within the scatter of the next); then compound 2.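

The change from 4-propylphenyl to 4-ethylphenyl gives a 1.2-fold higher number from compound 3 to compound 4 (0.09 log units; within the scatter) in this assay. Going by these compounds alone, this is the first measured change on this chain, and removing methyl at this place leaves the number within the scatter. No evidence at hand bears on this result.

Going by these compounds, what remains open is whether the chain can be changed further with as little consequence: a longer chain, such as butyl, or a methyl in place of the ethyl might behave differently. An amine or a carboxylic acid at the end of the chain is equally unresolved.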